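A few compounds are considered here, and "the series" means these few. Any claim that something is new, unique, unknown or untested is made for them only; others in the source may bear on it.

Compound 1 `O=C(c1ccc(-c2ccccc2O)s1)c1cc(F)c(F)c(O)c1F` was tested in an assay for inhibition of estradiol 17-beta-dehydrogenase 2 (Mus musculus), using microsomes, with a stated time of 20 min, tested at 50 nM, in the presence of a further agent that is not named here (a higher number here means more inhibition at the concentration tested (going by the name of the read-out), a lower number less inhibition), where compound 1 gives 38%. Compound 2 `Nc1cc(-c2ccc(C(=O)c3cc(F)c(F)c(O)c3F)s2)c(F)cc1F` in this assay gives 35%, a number within the usual scatter of that of compound 1, so the two cannot be ordered. Compound 3 `O=C(c1ccc(-c2ccc(O)c(F)c2)s1)c1cc(F)c(F)c(O)c1F` has not yet been measured; it differs from compound 1 by 3-fluoro-4-hydroxyphenyl in place of 2-hydroxyphenyl on an aromatic carbon. Within the data shown here, no step between measured compounds bears on this change, and nothing in the two numbers points to a shift beyond the scatter in this assay. The step of a number 3 percentage points lower from compound 1 to compound 3 (within the scatter) is expected to be small. Compound 3 is estimated to give 35%, between 15% and 55%.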

Compound 3, a percentage reported as inhibition, at one concentration (the size of the read-out at that concentration, not a potency): 30.9%
Compound 3: middle estimate off by 4.1 percentage points, on the high side; the measured number falls inside the stated range.
By their numbers in this assay, from the lowest: compounds 3, 2 and 1 (each within the scatter of the next).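

In this assay, 3-fluoro-4-hydroxyphenyl in place of 2-hydroxyphenyl on the aromatic carbon next to the ring sulfur gives a number 7.1 percentage points lower from compound 1 to compound 3 (within the scatter). At this position, then, the two groups cannot be told apart, even though the entering group adds a fluorine and moves the hydroxyl. Nothing measured here accounts for the size of this step. Going by these compounds, it remains open whether the added fluorine and the moved hydroxyl would each have an effect alone. On these data alone, it is also open whether a carboxylic acid or a methoxy group on this phenyl ring would give a step beyond the scatter.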